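Replacing the aryl group on a shared core

This account rests on a few compounds, and the source may have more. Where it says the series, first, only, none or still open, it means among the compounds named here.

Three compounds share one core and differ in the group on its carbonyl. In a functional assay on Shh Light II cells (Mus musculus) for inhibition, read by a luciferase reporter (a lower number here means a stronger inhibitor, a higher number a weaker inhibitor), compound 1 `O=C(OC1CCCCC1)N1CCC(c2nc(-c3ccc4ccccc4n3)no2)CC1` gives 580 nM, compound 2 `COc1ccccc1N(C)C(=O)N1CCC(c2nc(-c3ccc4ccccc4n3)no2)CC1` gives 3100 nM and compound 3 `O=C(Nc1ccccc1C(F)(F)F)N1CCC(c2nc(-c3ccc4ccccc4n3)no2)CC1` gives 700 nM. Compound 3 is thus level with compound 1 and clearly stronger than compound 2. The measured gaps show this: a 1.2-fold higher number from compound 1 to compound 3 (0.08 log units; within the scatter), whereas a 4.4-fold lower number from compound 2 to compound 3 (0.65 log units; beyond the scatter).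

Compound 4 `O=C(Nc1ncccc1Cl)N1CCC(c2nc(-c3ccc4ccccc4n3)no2)CC1` has 3-chloropyridin-2-yl in place of 2-(trifluoromethyl)phenyl on an amide-type nitrogen. Among the compounds with values here, no measured step makes this exact swap. The nearest guides are the changes at the same carbonyl, and the largest of them is a 5.3-fold higher number from compound 1 to compound 2 (0.73 log units; beyond the scatter). Those steps range from nothing beyond the scatter to modest, so a large jump in this assay seems unlikely. The expected change is small, a 1.3-fold higher number from compound 3 to compound 4 (0.11 log units; within the scatter), and it probably stays within the scatter. For compound 4 the estimate is 900 nM, with an expected range of 300 nM to 2700 nM.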

Compound 4, half-maximal inhibitory concentration: 2800 nM
The estimate for compound 4 lay 3.1-fold (0.49 log units) below the measured number, and the stated range ends below it.
By their numbers in this assay, from the lowest: compounds 1 and 3 (each within the scatter of the next); then compounds 4 and 2 (each within the scatter of the next).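

In this assay, the aryl group on the amide-type nitrogen clearly matters: placing 3-chloropyridin-2-yl there gives a 4.0-fold higher number from compound 3 to compound 4 (0.60 log units; beyond the scatter). Keeping the amide hydrogen is also not enough to hold the number near that of compound 1, since the new group gives a 4.8-fold higher number from compound 1 to compound 4 (0.68 log units; beyond the scatter), while compound 4 sits level with compound 2, which has a methyl on that nitrogen, at a 1.1-fold lower number from compound 2 to compound 4 (0.04 log units; within the scatter). Nothing measured here explains why the number rises with this swap.

The swap changes the ring atoms and the substituent together, so these compounds cannot show which change accounts for the step. A chlorophenyl group or a trifluoromethylpyridinyl group on the same nitrogen would separate the two changes.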